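Extending Trifluoromethoxy to a Biaryl: Effect on Solubility

A few compounds are considered here, and "the series" means these few. Any claim that something is new, unique, unknown or untested is made for them only; others in the source may bear on it.

Measured compounds and their values in a physicochemical assay for solubility, read by HPLC, measured as kinetic solubility, at pH 7; a higher number here means a more soluble compound, a lower number a less soluble compound:
compound 1, `O=C(Nc1ccc(OC(F)(F)F)cc1)N[C@@H]1COc2nc([N+](=O)[O-])cn2C1`: 93 ug/mL
compound 2, `O=C(NCc1ccc(OC(F)(F)F)cc1)O[C@@H]1COc2nc([N+](=O)[O-])cn2C1`: 10 ug/mL
compound 3, `O=C(Nc1ccc(-c2ccc(OC(F)(F)F)cc2)cc1)N[C@@H]1COc2nc([N+](=O)[O-])cn2C1`: 0.17 ug/mL

Compound 1 and compound 2 share much of their structure, but the difference between the two cores is not broken down here. Compound 3 differs from compound 1 by one change, (4-(trifluoromethoxy)phenyl in place of trifluoromethoxy on an aromatic carbon), and that change gave a 550-fold lower number from compound 1 to compound 3 (2.74 log units; beyond the scatter). The unmeasured compound 4, `O=C(NCc1ccc(-c2ccc(OC(F)(F)F)cc2)cc1)O[C@@H]1COc2nc([N+](=O)[O-])cn2C1`, differs from compound 2 by the same change at the same place, (4-(trifluoromethoxy)phenyl in place of trifluoromethoxy on an aromatic carbon). Within the data shown here, a step of similar size is therefore expected from compound 2 to compound 4, a 330-fold lower number from compound 2 to compound 4 (2.52 log units; beyond the scatter), resting on the single measured pair of compound 1 and compound 3. Starting from compound 2, the value expected for compound 4 in this assay is about 0.03 ug/mL, likely between 0.008 ug/mL and 0.2 ug/mL.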

Compound 4, solubility: 0.34 ug/mL
Beside the measured number, compound 4's estimate is 11-fold (1.05 log units) below it; measured number outside the range, above it.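

In this assay, putting 4-(trifluoromethoxy)phenyl in place of trifluoromethoxy lowers the number on both cores, with a 550-fold lower number from compound 1 to compound 3 (2.74 log units; beyond the scatter) and a 29-fold lower number from compound 2 to compound 4 (1.47 log units; beyond the scatter). The direction of the change therefore carried from one core to the other, but its size did not, since the step on the core of compound 2 is the smaller of the two. Two pairs make no general rule, and nothing measured here explains the difference in size.

As far as these compounds go, it remains open how an amine or a carboxylic acid in place of trifluoromethoxy would behave on the longer biaryl compounds. From the compounds shown here alone, it also remains open what size of step the same change would give on a third core.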